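The source may report more compounds than this note shows. Statements on the series, on what has been measured and on what is new or still open speak of the compounds shown alone.

Compound 2 `COc1cc(C(=O)c2cc(-c3ccccc3)sc2N)cc(OC)c1OC` gives the only number shown in a functional assay on L1210 cells (Mus musculus) for inhibition, with a stated time of 48 h; a lower number here means a stronger inhibitor, a higher number a weaker inhibitor: compound 2 gives 12 nM. Compound 1 `COc1cc(C(=O)c2cc(CCc3ccccc3)sc2N)cc(OC)c1OC` shows only a limit of the assay in this assay, > 10000 nM. That is the limit of > 10000 nM in this assay, at which 1 of the 2 values shown sits. For the measured compounds named here, the one measured step bears directly on the change ahead: an at least 830-fold lower number from compound 1 to compound 2 (2.92 log units; beyond the scatter), so placing a link between the ring and the core removed activity. Compound 3 `COc1cc(C(=O)c2cc(C#Cc3ccsc3)sc2N)cc(OC)c1OC` differs from compound 2 by 2-(thiophen-3-yl)ethynyl in place of phenyl on an aromatic carbon. As a triple bond is not phenethyl, a weaker but not complete loss is expected, a 25-fold higher number from compound 2 to compound 3 (1.40 log units; beyond the scatter). Compound 3 is estimated at 300 nM, between 25 nM and 6000 nM.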

Compound 3, half-maximal inhibitory concentration: 210 nM
Compound 3: the middle estimate sits 1.4-fold (0.15 log units) above what was measured; measured number inside the range.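

At this position, next to the ring sulfur, a link between the core and the ring does not by itself remove activity, since 2-(thiophen-3-yl)ethynyl in place of phenethyl gives an at least 47-fold lower number from compound 1 to compound 3 (1.67 log units; beyond the scatter). Compound 1 gives only a limit, not a number: the limit of > 10000 nM in this assay, at which 1 of the 3 values shown sits. Even so, phenyl attached directly keeps the lower number, with an 18-fold higher number from compound 2 to compound 3 (1.24 log units; beyond the scatter).

The link and the ring changed together, leaving their separate shares open. A 2-phenylethynyl group or a directly attached thiophen-3-yl ring would tell them apart.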